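Methyl-to-hydrogen steps across a shared core

This account rests on a few compounds, and the source may have more. Where it says the series, first, only, none or still open, it means among the compounds named here.

Compound 2 `Cc1ccc2ncc(C(=O)c3sc(N)nc3-c3ccccc3)n2c1` gives 77% in a functional assay on the whole organism (strain Sprague-Dawley) for inhibition, with Rattus norvegicus as the target, read by paw edema, with stated times of 1 h and 3 h, at a dose of 50 mg/kg by the oral route; on this read-out higher numbers stand for more inhibition at the one dose given (going by the name of the read-out) and lower numbers for less inhibition. Compound 1 `Nc1nc(-c2ccccc2)c(C(=O)c2cnc3ccccn23)s1` gives 40% in this assay, and compound 3 `Cc1nc(N)sc1C(=O)c1cnc2ccccn12` gives 53%. Between compound 2 and compound 1 the change is hydrogen in place of methyl on an aromatic carbon; it brings a number 37 percentage points lower from compound 2 to compound 1 (beyond the scatter). The change from compound 1 to compound 3 brings a number 13 percentage points higher from compound 1 to compound 3 (beyond the scatter). The difference between the cores of compound 2 and compound 3 is not broken down here. Compound 4 `Nc1ncc(C(=O)c2cnc3ccccn23)s1` is not yet measured; it differs from compound 3 by hydrogen in place of methyl on an aromatic carbon. This is the same kind of change as that from compound 2 to compound 1, but the place differs: there the methyl sat on a six-membered aromatic ring with one nitrogen in a fused system, here on a five-membered aromatic ring with one nitrogen and one sulfur. A drop is expected for compound 4 because the earlier step of a number 37 percentage points lower from compound 2 to compound 1 (beyond the scatter) was large, though a smaller one for the different place. For compound 4 the estimated step is a number 20 percentage points lower from compound 3 to compound 4 (beyond the scatter). Compound 4 is expected to give 33%, with a likely range from 15% to 55%.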

Compound 4, a percentage reported as inhibition, in the whole organism at one dose (the size of the read-out at that dose, not a potency): 33%
The estimate for compound 4 equals the measured number at the digits printed, and the stated range covers the measured number.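

Hydrogen in place of methyl on an aromatic carbon lowers the number on both cores in this assay, but the size of the step does not carry over from one core to the other: the same change on two cores in this assay, a number 37 percentage points lower (beyond the scatter) from compound 2 to compound 1 and a number 20 percentage points lower (beyond the scatter) from compound 3 to compound 4, 17 percentage points apart, beyond the scatter of two such steps

On the core of compound 3, the change gives a number 20 percentage points lower from compound 3 to compound 4 (beyond the scatter), while hydrogen in place of phenyl on the same carbon gives a number 7 percentage points lower from compound 1 to compound 4 (within the scatter). For the compounds shown here, with only two examples, and the methyl in a different place on each core, these steps do not show whether the core or the place sets the size.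

The compounds shown leave open how an ethyl group or a carboxylic acid on that carbon would read. They also leave open what an amide in place of the amino group would give.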